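Swapping phenyl for trifluoromethyl on compound 2

The source may report more compounds than this note shows. Statements on the series, on what has been measured and on what is new or still open speak of the compounds shown alone.

Values so far in a functional assay on KG-1 cells (Homo sapiens) for cytotoxicity, read by luminescence and CellTiter-Glo, with a stated time of 3 days; a lower number here means a stronger inhibitor, a higher number a weaker inhibitor:
compound 1 `O=C(Nc1cc(F)cc(F)c1)c1ccc2cccnc2c1O` gives 3340 nM
compound 2 `N#Cc1ccc(NC(=O)c2cc(-c3ccccc3)ccc2O)cc1` gives 1300 nM
compound 3 `O=C(Nc1ccc(C(F)(F)F)cc1)c1cc(Cl)c(-c2ccccc2)cc1O` gives 770 nM

Compound 2 at 1300 nM cannot be told apart from compound 3 at 770 nM in these data. The two lie within the usual scatter of repeat measurements. Compound 1 at 3340 nM has a higher number than compound 2, and that gap is beyond the scatter.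

The next compound, compound 4 `N#Cc1ccc(NC(=O)c2cc(C(F)(F)F)ccc2O)cc1`, is compound 2 with one change: trifluoromethyl in place of phenyl on an aromatic carbon. Among the measured compounds shown here, no measured pair shows this change alone, so the size of the step in this assay is uncertain. Compound 1, which carries no plain phenyl, gives 3340 nM in this test, so a small move toward a weaker inhibitor is expected rather than a gain. The expected step is a 1.7-fold higher number from compound 2 to compound 4 (0.23 log units; within the scatter) and points toward a higher number. For compound 4 the estimated value is 2200 nM, with an expected range from 700 nM to 7000 nM.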

Compound 4, half-maximal inhibitory concentration: 4810 nM
Estimate against measurement, compound 4: 2.2-fold (0.34 log units) below; low and high end bracket the measured number.
By their numbers in this assay, from the lowest: compounds 3 and 2 (each within the scatter of the next); then compounds 1 and 4 (each within the scatter of the next).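

Among the compounds shown here, replacing phenyl with trifluoromethyl on an aromatic carbon, para to the hydroxy group, gives a 3.7-fold higher number from compound 2 to compound 4 (0.57 log units; beyond the scatter) in this assay, the first direct reading of a change at this position. The earlier compounds shown here differed in several places at once and could not isolate one group, whereas this pair shows that the group held here matters and that, in this one pair, phenyl gives the stronger inhibitor. Nothing measured here shows why the phenyl compound is the stronger one.

This single pair cannot separate the loss of the ring from the arrival of trifluoromethyl. On these data alone, it remains open how a methyl group, an amine or a carboxylic acid would read at this position, and whether the same step would appear with other groups elsewhere on the shared core.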